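Moving the indole attachment: compound 2 to compound 3

This account rests on a few compounds, and the source may have more. Where it says the series, first, only, none or still open, it means among the compounds named here.

Measured in a functional assay on HeLa cells (Homo sapiens) for inhibition, read by CCK-8 assay, with a stated time of 48 h; a higher number here means a weaker inhibitor, a lower number a stronger inhibitor:
- compound 1 `COc1cc(-c2ccnc3cc(-c4ccc(F)cc4)nn23)cc(OC)c1OC`: 5840 nM
- compound 2 `COc1cc(-c2ccnc3cc(-c4cn(C)c5ccccc45)nn23)cc(OC)c1OC`: 399 nM

Compound 2 holds the lower of the two numbers. Compound 3 `COc1cc(-c2ccnc3cc(-c4ccc5ccn(C)c5c4)nn23)cc(OC)c1OC` differs from it as follows: 1-methyl-1H-indol-6-yl in place of 1-methyl-1H-indol-3-yl on an aromatic carbon. For the measured compounds named here, one measured step bears on this, a 15-fold lower number from compound 1 to compound 2 (1.17 log units; beyond the scatter), a large step at the same aromatic carbon. Going by the values given here, it swaps a different group, and no measured pair tests the indole attachment point. A higher number in this assay is expected, of moderate size, and the direction remains uncertain. The expected step is a 2.3-fold higher number from compound 2 to compound 3 (0.35 log units; beyond the scatter). For compound 3 the estimate is 900 nM, with an expected range of 150 nM to 5000 nM.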

Compound 3, half-maximal inhibitory concentration: 187 nM
The estimate for compound 3 lay 4.8-fold (0.68 log units) above the measured number; measured number inside the range.
By their numbers in this assay, from the lowest: compound 3; then compound 2; then compound 1.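

In this assay, the attachment point of the indole counts at this aromatic carbon: 1-methyl-1H-indol-6-yl in place of 1-methyl-1H-indol-3-yl gives a 2.1-fold lower number from compound 2 to compound 3 (0.33 log units; beyond the scatter) with the same atoms joined differently. Replacing 4-fluorophenyl with 1-methyl-1H-indol-6-yl gives a 31-fold lower number from compound 1 to compound 3 (1.49 log units; beyond the scatter) and so extends the large gain already seen with the 1-methyl-1H-indol-3-yl group. Nothing at hand explains the difference between the two attachments. Still open, from the compounds shown here alone, is whether the methyl on the indole nitrogen is needed, and whether an amine or a carboxylic acid on the indole would be tolerated.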